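Ethoxy for Iodo on the Aryl Hydrazone Ring

The source may report more compounds than this note shows. Statements on the series, on what has been measured and on what is new or still open speak of the compounds shown alone.

Three compounds share one core and differ only in the ring attached to the hydrazone nitrogen. Compound 1 `CC1CC/C(=N\Nc2ccccc2Cl)c2ncc(C(=O)O)c(=O)n21` carries a chloro group there; compound 2 `CC1CC/C(=N\Nc2ccccc2I)c2ncc(C(=O)O)c(=O)n21` carries an iodo group; compound 3 `CC1CC/C(=N\Nc2ccc(O)cc2)c2ncc(C(=O)O)c(=O)n21` carries a 4-hydroxyphenyl group. In a functional assay on the whole organism for inhibition, with Rattus norvegicus as the target (a lower number here means that less compound is needed, a higher number that more compound is needed for the effect), compound 1 gives > 1000 umol/kg, which is a limit rather than a number. In this assay compound 2 likewise gives only the limit > 1000 umol/kg. Compound 3 gives > 100 umol/kg, again a limit. Because two values sit at the limit of > 1000 umol/kg in this assay, at which 2 of the 3 values shown sit, and one at the limit of > 100 umol/kg in this assay, at which 1 of the 3 values shown sits, none of the steps between them can be read: a step that the two limits leave unreadable from compound 1 to compound 2, a step that the two limits leave unreadable from compound 1 to compound 3 and a step that the two limits leave unreadable from compound 2 to compound 3 are all left open by their limits. Compound 2 therefore stands only at a limit, as do the other two values shown.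

Compound 4 `CCOc1ccccc1N/N=C1\CCC(C)n2c1ncc(C(=O)O)c2=O` is not yet measured. It differs from compound 2 by ethoxy in place of iodo on an aromatic carbon. The measured steps that touch this place are the swap from compound 1 to compound 2 and the change from compound 2 to compound 3, and both are unreadable, so no direction or size can be inferred. With every known value at a limit, compound 4 is expected to behave similarly, and its estimated step of a number no higher from compound 2 to compound 4 (the limit leaves the size open) is expected to be none beyond the scatter. Compound 4 is estimated at 1000 umol/kg, within a range from 300 umol/kg to 3000 umol/kg.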

Compound 4, dose for 50% inhibition: > 1000 umol/kg
Compound 4 was reported as a limit (the forecaster's own chance of this, stated with the estimate: 75%); the middle value lies on the limit itself.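

In this assay compound 4 gives > 1000 umol/kg, which is a limit and not a number, so its steps to compound 1 and compound 2 cannot be read. The compounds shown leave open whether ethoxy, iodo or chloro on the aromatic ring changes the dose needed at all.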